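From fluorophenyl to aminophenyl on a shared core

The source may hold more compounds than are shown below. What is called first, only, known or untested is meant among the compounds shown, and "the series" means these compounds.

Compound 1 `O=C(Nc1cccc(F)c1)c1cc(=O)[nH]c2cc(-c3ccc(F)cc3)ccc12`: 10300 nM
Compound 2 `O=C(Nc1cccc(F)c1)c1cc(=O)[nH]c2cc(-c3cccc(F)c3)ccc12`: 10900 nM

Both compounds were tested in a functional assay on KYSE-410 cells (Homo sapiens) for antiproliferative activity, read by MTT assay, with a stated time of 72 h; on this read-out lower numbers stand for stronger inhibition and higher numbers for weaker inhibition. Going by the values given here, there compound 2 gives 10900 nM and stands level with compound 1, the only other compound measured so far. The measured step between them is a 1.1-fold higher number from compound 1 to compound 2 (0.02 log units; within the scatter).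

Compound 3 `Nc1ccc(-c2ccc3c(C(=O)Nc4cccc(F)c4)cc(=O)[nH]c3c2)cc1` keeps the shared core and differs from compound 2 in one place: 4-aminophenyl in place of 3-fluorophenyl on an aromatic carbon. Put simply, it carries 4-aminophenyl in place of 3-fluorophenyl on an aromatic carbon.

Among the compounds with values here, only one measured step bears on this change, and it is a weak guide. That step, a 1.1-fold higher number from compound 1 to compound 2 (0.02 log units; within the scatter), merely put 3-fluorophenyl in place of 4-fluorophenyl. Within the data shown here, no measured compound carries 4-aminophenyl, so the data give no firm direction. A small expected shift towards stronger inhibition is therefore a tentative guess, and the estimated change is a 1.8-fold lower number from compound 2 to compound 3 (0.26 log units; within the scatter). For compound 3 the expected value is 6000 nM, with an estimated range from 1500 nM to 20000 nM.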

Compound 3, half-maximal inhibitory concentration: > 20000 nM
Compound 3 was reported as a limit; the forecaster's own chance of this, stated with the estimate: 10%; middle value at least 3.3-fold (0.52 log units) away from the limit.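

In this assay compound 3 gives > 20000 nM, which is a limit of the assay and not a number, so the true value is unknown: the limit of > 20000 nM in this assay, at which 1 of the 3 values shown sits.

Read as floors, the two new steps are an at least 1.8-fold higher number from compound 2 to compound 3 (0.26 log units; that floor lies within the scatter) and an at least 1.9-fold higher number from compound 1 to compound 3 (0.28 log units; that floor lies within the scatter); the second is the cleaner comparison, since amino simply takes the place of fluoro on the same phenyl carbon. Going by these compounds alone, the earlier pair showed only that two fluorophenyl groups stand level in this place, whereas 4-aminophenyl, the only group here counted with a hydrogen-bond donor, brings no move towards a lower number, so the shift towards stronger inhibition does not appear. Both floors lie within the scatter, so compound 3 cannot yet be called weaker than compound 1 or compound 2, although the real gap could be much wider.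

The compounds shown leave open how far the true value of compound 3 lies past its limit. They also cannot separate the effect of the amino group from that of its place on the ring, a question that a 3-aminophenyl group, or a 4-hydroxyphenyl group, on the same aromatic carbon would address.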